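Series notes: acyl in place of benzyl on the ring nitrogen

The source may report more compounds than this note shows. Statements on the series, on what has been measured and on what is new or still open speak of the compounds shown alone.

Going by the values given here, compound 1 `CCCCNc1nc(N)nc2c1CN(Cc1ccccc1Cl)CC2` gives 0.05 uM in an assay on HEK293 cells for agonist activity at Toll-like receptor 8 (Homo sapiens), read by a luciferase reporter, with a stated time of 6 h (on this read-out lower numbers stand for an effect already at smaller amounts and higher numbers for an effect only at larger amounts of compound), the lowest of the three numbers measured so far. Compound 3 `CCCCNc1nc(N)nc2c1CN(Cc1ccc(OC)cc1)CC2` gives 0.08 uM and sits within the scatter of compound 1, so no order between the two can be claimed; compound 2 `CCCCNc1nc(N)nc2c1CN(Cc1cccc(Cl)c1Cl)CC2` gives 0.18 uM and lies beyond it, with a 3.6-fold higher number from compound 1 to compound 2 (0.56 log units; beyond the scatter).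

Compound 4 `CCCCNc1nc(N)nc2c1CN(C(=O)c1ccccn1)CC2` differs from compound 1 as follows: (pyridin-2-yl)carbonyl in place of 2-chlorobenzyl on an amine nitrogen in a ring.

The measured steps bear on this change only loosely. Both a 3.6-fold higher number from compound 1 to compound 2 (0.56 log units; beyond the scatter) and a 1.6-fold higher number from compound 1 to compound 3 (0.20 log units; within the scatter) keep a benzyl attached to the ring nitrogen and vary only the aromatic ring on it; a 2.3-fold lower number from compound 2 to compound 3 (0.35 log units; beyond the scatter) does likewise. None of them replaces the saturated chain carbon at the nitrogen with a carbonyl, and none introduces a ring bearing a hetero atom at this place. The change in compound 4 is therefore outside what the three measured compounds cover, and the expected step is uncertain in size. Given that compound 1 already holds the lowest number, a step beyond the scatter toward a higher number is expected, estimated as a 10-fold higher number from compound 1 to compound 4 (1.00 log units; beyond the scatter). Compound 4 is expected to give 0.5 uM, with a range from 0.1 uM to 3 uM.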

Compound 4, minimum effective concentration: 2.9 uM
For compound 4 the middle estimate is 5.8-fold (0.76 log units) below the measured one; measured number inside the range.
By their numbers in this assay, from the lowest: compounds 1 and 3 (each within the scatter of the next); then compound 2; then compound 4.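

In this assay, the replacement on the amine nitrogen in a ring gives a 58-fold higher number from compound 1 to compound 4 (1.76 log units; beyond the scatter), a much larger step than any seen while a benzyl stayed in place, where the widest step from compound 1 was a 3.6-fold higher number from compound 1 to compound 2 (0.56 log units; beyond the scatter). This place is therefore sensitive to what is attached directly to the nitrogen, not only to the substituents on the aromatic ring of a benzyl group. The step from 2-chlorobenzyl to (pyridin-2-yl)carbonyl changes several things at once, bringing in a carbonyl, a ring with a hetero atom and hydrogen-bond acceptors while removing the chlorine, and nothing available here gives a measured reason for the higher number.

The compounds shown leave open how much of the step belongs to the carbonyl and how much to the pyridine ring: a benzoyl group would pair the carbonyl with a ring of carbon only, while a pyridin-2-ylmethyl group would pair the saturated chain carbon with the pyridine ring. As far as these compounds go, it also remains open whether other acyl groups on this nitrogen, such as acetyl, follow compound 4.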